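Methyl on the Ring Amine Nitrogen in Two Cores

A few compounds are considered here, and "the series" means these few. Any claim that something is new, unique, unknown or untested is made for them only; others in the source may bear on it.

Compound 1 `c1ccc2c(c1)ccn2-c1nc(N2CCNCC2)nc2ccccc12` and compound 3 `Cn1cc(-c2nc(N3CCNCC3)nc3ccccc23)c2ccccc21` carry the same piperazin-1-yl group on related but distinct cores; the difference between the two cores is not broken down here. Among the measured compounds shown here, in an ADME assay on Vero cells (Chlorocebus sabaeus) for antiproliferative activity, read by MTT assay (on this read-out higher numbers stand for weaker inhibition and lower numbers for stronger inhibition), compound 1 gives 8.9 ug/mL, while compound 3 gives 50 ug/mL, the highest of the three numbers measured so far, with compound 1 the furthest from it.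

Compound 2 `CN1CCN(c2nc(-n3ccc4ccccc43)c3ccccc3n2)CC1` is compound 1 with one change, (methyl in place of hydrogen on an amine nitrogen in a ring), giving piperazin-1-yl to 4-methylpiperazin-1-yl. In this assay compound 2 gives 22.3 ug/mL, so the change made a 2.5-fold higher number from compound 1 to compound 2 (0.40 log units; beyond the scatter).

Compound 4 `CN1CCN(c2nc(-c3cn(C)c4ccccc34)c3ccccc3n2)CC1` stands to compound 3 exactly as compound 2 stands to compound 1: the change is methyl in place of hydrogen on an amine nitrogen in a ring, at the same place, described in the same words, so it is the same change on a different core.

For the measured compounds named here, only one measured instance of this change exists, and it moved the number upward. Going by the values given here, the step from compound 3 to compound 4 in this assay is expected to be of similar size, a 2.2-fold higher number from compound 3 to compound 4 (0.34 log units; beyond the scatter), because the single precedent is a 2.5-fold higher number from compound 1 to compound 2 (0.40 log units; beyond the scatter) and nothing among the compounds measured argues against carrying it across. The range is kept wide because compound 3 already gives 50 ug/mL, and a single precedent on a different core is a thin basis for the size of the step.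

Compound 4 is expected to give about 110 ug/mL, estimated between 50 ug/mL and 250 ug/mL.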

Compound 4, half-maximal inhibitory concentration: 50 ug/mL
Compound 4: the middle estimate sits 2.2-fold (0.34 log units) above what was measured, within the range that was stated.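

In this assay methyl in place of hydrogen on the ring amine nitrogen gives no change at the digits printed from compound 3 to compound 4 (within the scatter), and set beside the earlier step, the two cores do not separate: the same change on two cores in this assay, a 2.5-fold higher number (0.40 log units; beyond the scatter) from compound 1 to compound 2 and no change at the digits printed (within the scatter) from compound 3 to compound 4, 2.5-fold (0.40 log units) apart, within the scatter of two such steps. This shows that the two measured instances of the change are compatible with each other, even though one step taken alone lies beyond the scatter and the other lies within it. It does not show that the core alters the effect of the change, nor that the change carries over with one fixed size, as a single pair on each core can establish neither a shared step nor a real difference between the two.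

Open, going by these compounds, is whether a group larger than methyl on the same nitrogen, such as ethyl, a longer chain or an acetyl group, would behave alike on both cores. Also open, on these data alone, is whether the same comparison would hold on either core if the piperazine gave way to another cyclic amine, such as morpholine or piperidine, or to an open-chain amine.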